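Antiproliferative series: step from compound 3 to compound 4

The source may hold more compounds than are shown below. What is called first, only, known or untested is meant among the compounds shown, and "the series" means these compounds.

Measured so far in a functional assay on MDA-MB-231 cells (Homo sapiens) for antiproliferative activity, read by MTT assay, with a stated time of 24 h; on this read-out higher numbers stand for weaker inhibition and lower numbers for stronger inhibition:
compound 1 `COc1cc(/C=C/C(=O)c2cc(-c3cc(OC)c(OC)c(OC)c3)n3nc(-c4ccccc4)cc3n2)cc(OC)c1OC` gives 18400 nM
compound 2 `COc1cc(-c2cc(C(=O)/C=C/c3ccc(C)cc3)nc3cc(-c4ccccc4)nn23)cc(OC)c1OC` gives 18600 nM
compound 3 `COc1cc(-c2cc(C(=O)/C=C/c3ccc(Cl)cc3)nc3cc(-c4ccccc4)nn23)cc(OC)c1OC` gives 21600 nM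

Compound 3 has the highest of the three numbers, but its nearest neighbour compound 2 and its furthest neighbour compound 1 both sit within the scatter, so no order among the three can be read. Compound 4 `COc1cc(-c2cc(/C=C/C(=O)c3ccccc3)nc3cc(-c4ccccc4)nn23)cc(OC)c1OC` differs from compound 3 by 2-benzoylethenyl in place of (2-(4-chlorophenyl)ethenyl)carbonyl on an aromatic carbon. Going by the values given here, no measured step changes the chain in this way; the steps of a 1.2-fold higher number from compound 1 to compound 3 (0.07 log units; within the scatter) and a 1.2-fold higher number from compound 2 to compound 3 (0.06 log units; within the scatter) only vary the aryl end of the chain and both stay within the scatter. The expectation for compound 4 is therefore a step of a 1.1-fold lower number from compound 3 to compound 4 (0.03 log units; within the scatter), none beyond the scatter, with a wide range. Compound 4 is estimated at 20000 nM, between 7000 nM and 55000 nM.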

Compound 4, half-maximal inhibitory concentration: 15800 nM
Compound 4: middle estimate off by 1.3-fold (0.10 log units), on the high side; the range from low to high includes it.
By their numbers in this assay, from the lowest: compounds 4, 1, 2 and 3 (each within the scatter of the next).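

In this assay, going by these compounds alone, the first step that changes the chain itself rather than its aryl end, 2-benzoylethenyl in place of (2-(4-chlorophenyl)ethenyl)carbonyl, gives a 1.4-fold lower number from compound 3 to compound 4 (0.14 log units; within the scatter), and in place of (2-(4-methylphenyl)ethenyl)carbonyl it gives a 1.2-fold lower number from compound 2 to compound 4 (0.07 log units; within the scatter). This aromatic carbon next to the ring nitrogen therefore accepts the 2-benzoylethenyl chain with no step beyond the scatter, although each step also changes the substituent on the aryl end. No supporting data bear on this result.

Still open, as far as these compounds go, is whether an amine or a carboxylic acid on the benzoyl ring would move the number beyond the scatter. A longer chain at this carbon is equally untested in the compounds shown.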